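The source may report more compounds than this note shows. Statements on the series, on what has been measured and on what is new or still open speak of the compounds shown alone.

Measured so far in an assay on isolated protein for inhibition of high affinity 3',5'-cyclic-AMP phosphodiesterase 7A (Homo sapiens), read by cAMP accumulation, with a stated time of 10 min; a higher number here means a weaker inhibitor, a lower number a stronger inhibitor:
Compound 1, `COc1nc2c(c(=O)n(C)c(=O)n2C)n1CC(=O)NCc1ccccc1Cl`, gives > 200000 nM, which is a limit of the assay and not a number.
Compound 2, `COc1nc2c(c(=O)n(C)c(=O)n2C)n1CCCC(=O)Nc1cccc(Cl)c1`, gives > 200000 nM, again a limit rather than a number.

For the measured compounds named here, compound 2 thus stands only at a limit; the one other value shown is likewise a limit, and both sit at the limit of > 200000 nM in this assay, at which 2 of the 2 values shown sit. Going by the values given here, no step between two measured compounds is available, so no measured change can be pointed to.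

Compound 3, `COc1nc2c(c(=O)n(C)c(=O)n2C)n1CCCC(=O)Nc1ccc(C(C)(C)C)cc1`, differs from compound 2 in one place: 4-(tert-butyl)phenyl in place of 3-chlorophenyl on an amide-type nitrogen. With compound 2 at a limit, neither direction nor size of this step can be read from the data. For compound 3 the expected step is a step that the limit leaves unreadable from compound 2 to compound 3, no clear change beyond the scatter. Compound 3 is therefore estimated at 250000 nM, between 50000 nM and 1000000 nM, and most likely reported once more only as a limit.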

Compound 3, half-maximal inhibitory concentration: 19800 nM
For compound 3 the middle estimate is 13-fold (1.10 log units) above the measured one; measured number outside the range, below it.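

In this assay, the group on the amide-type nitrogen proves able to change the result: 4-(tert-butyl)phenyl in place of 3-chlorophenyl gives an at least 10-fold lower number from compound 2 to compound 3 (1.00 log units; beyond the scatter). Both groups contain one six-membered aromatic ring of carbon only, so the step lies in what that ring carries, or where it carries it, and not in the kind of ring. Compound 3 is also the only compound shown with a measured number instead of a limit of the assay: the limit of > 200000 nM in this assay, at which 2 of the 3 values shown sit.

As far as these compounds go, whether the step follows the tert-butyl group itself or its place on the ring remains open, as the group and its place both change together here. The compounds shown also leave open how an amine or a carboxylic acid on that ring would read.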